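Lengthening a side chain on a hydroxylated lactam core

The source may report more compounds than this note shows. Statements on the series, on what has been measured and on what is new or still open speak of the compounds shown alone.

Compound 1, `CCCCCC1(O)C(=O)Nc2ccc(Nc3ccc(F)cc3)cc21`, was tested in a functional assay on NCI-H460 cells (Homo sapiens) for antiproliferative activity, read by MTT assay, with a stated time of 48 h; on this read-out lower numbers stand for stronger inhibition and higher numbers for weaker inhibition. In this assay compound 1 gives only a limit, > 100000 nM, not a number. Compound 2, `CCCCCCC1(O)C(=O)Nc2ccc(Nc3ccc(F)cc3)cc21`, carries methyl in place of hydrogen on a saturated chain carbon, five bonds along the chain from a saturated ring carbon and gives 50700 nM in this assay, a change of an at least 1.9-fold lower number from compound 1 to compound 2 (0.29 log units; that floor lies within the scatter). That step is only a floor because compound 1 sits at the limit of > 100000 nM in this assay, at which 1 of the 3 values shown sits.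

Compound 3, `CCCCC1(O)C(=O)Nc2ccc(Nc3ccc(C(F)(F)F)cc3)cc21`, has a different core; how the two cores differ is not broken down here. In this assay, among the measured compounds shown here, compound 3 gives 12000 nM, the lowest number so far.

Compound 4, `CCCCCC1(O)C(=O)Nc2ccc(Nc3ccc(C(F)(F)F)cc3)cc21`, has not yet been measured. It differs from compound 3 by methyl in place of hydrogen on a saturated chain carbon, four bonds along the chain from a saturated ring carbon. For the measured compounds named here, this is the same kind of change as the one from compound 1 to compound 2, but the added carbon sits four bonds along the chain from a saturated ring carbon rather than five.

The step from compound 3 to compound 4 is expected to be a 1.5-fold lower number from compound 3 to compound 4 (0.18 log units; within the scatter), resting on an at least 1.9-fold lower number from compound 1 to compound 2 (0.29 log units; that floor lies within the scatter). Compound 4 is therefore estimated at 8000 nM in this assay, between 3000 nM and 25000 nM.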

Compound 4, half-maximal inhibitory concentration: 16300 nM
Estimate against measurement, compound 4: 2.0-fold (0.31 log units) below; measured number inside the range.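

In this assay the added methyl gives a 1.4-fold higher number from compound 3 to compound 4 (0.13 log units; within the scatter), so on the core of compound 3 this small lengthening of the chain produces no clear change in either direction. Set beside the same change on the core of compound 1, the result reads: the same change on two cores in this assay, an at least 1.9-fold lower number (0.29 log units; that floor lies within the scatter) from compound 1 to compound 2 and a 1.4-fold higher number (0.13 log units; within the scatter) from compound 3 to compound 4; the limit leaves it open whether they differ. This does not show that the change carries over from one core to the other, nor that it fails to, since neither step can be told apart from the usual scatter of the measurement.

Trifluoromethyl in place of fluoro on an aromatic carbon gives an at least 6.1-fold lower number from compound 1 to compound 4 (0.78 log units; beyond the scatter), a real step whose full size remains open, since only its floor can be read. Among the compounds shown here, also open is whether a longer chain than the one in compound 4, or a nitrile in place of trifluoromethyl, would bring the number lower in this assay.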